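A few compounds are considered here, and "the series" means these few. Any claim that something is new, unique, unknown or untested is made for them only; others in the source may bear on it.

Within the data shown here, in a functional assay on QGY-7703 cells (Homo sapiens) for cytotoxicity, read by MTT assay, with a stated time of 24 h (a lower number here means a stronger inhibitor, a higher number a weaker inhibitor), compound 3 `O=C1/C(=C/c2ccncc2)CNC/C1=C\c1ccccc1F` gives 14200 nM, the highest of the three numbers measured so far. Compound 1 `CN1C/C(=C\c2ccncc2)C(=O)/C(=C/c2ccccc2F)C1` gives 4900 nM, and compound 2 `O=C1/C(=C/c2cccnc2)CN(S(=O)(=O)c2ccccc2)C/C1=C\c1ccccc1F` gives 4800 nM. Compound 4 `O=C1/C(=C/c2ccncc2)CN(S(=O)(=O)c2ccccc2)C/C1=C\c1ccccc1F` differs from compound 3 in one place: phenylsulfonyl in place of hydrogen on an amine nitrogen in a ring, with phenylsulfonyl in place of hydrogen on an amine nitrogen in a ring. Among the measured compounds shown here, the one measured step at this nitrogen is modest, a 2.9-fold higher number from compound 1 to compound 3 (0.46 log units; beyond the scatter), and there the compound with hydrogen has the higher number. Compound 2 also carries phenylsulfonyl on this nitrogen, though it differs elsewhere, and it stands at 4800 nM. A modest step to a lower number is therefore expected, namely a 2.8-fold lower number from compound 3 to compound 4 (0.45 log units; beyond the scatter). Compound 4 is estimated at 5000 nM, with an expected range of 2200 nM to 11000 nM.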

Compound 4, half-maximal inhibitory concentration: 8400 nM
Compound 4: middle estimate off by 1.7-fold (0.23 log units), on the low side, and the stated range covers the measured number.
By their numbers in this assay, from the lowest: compounds 2, 1, 4 and 3 (each within the scatter of the next, the first and the last beyond it).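

In this assay phenylsulfonyl in place of hydrogen on an amine nitrogen in a ring gives a 1.7-fold lower number from compound 3 to compound 4 (0.23 log units; within the scatter) and phenylsulfonyl in place of methyl gives a 1.7-fold higher number from compound 1 to compound 4 (0.23 log units; within the scatter) so neither change at this nitrogen stands clear of the scatter, unlike the earlier step from methyl to hydrogen. Pyridin-4-yl in place of pyridin-3-yl gives a 1.8-fold higher number from compound 2 to compound 4 (0.24 log units; within the scatter) and so this change also stays within the scatter. No measurement at hand bears on the reason for these results.

Still open, going by these compounds, is how an acetyl or benzyl group on this nitrogen would compare with phenylsulfonyl. Also open is how pyridin-2-yl would compare with the two pyridine groups shown.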